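Methyl on the amide nitrogen across two cores

The compounds below may be only part of what the source reports. "The series", "measured", "known", "first", "only" and "open" are said of these compounds alone.

Compound 1 `Cc1ccc(-c2nn(C(C)C)cc2C(=O)Nc2ccc(C)c(S(=O)(=O)N3CCOCC3)c2)cc1` is the reference point of this set. In an assay on isolated protein for antagonist activity at Bile acid receptor (Homo sapiens), read by TR-FRET, with a stated time of 20 min (on this read-out higher numbers stand for weaker inhibition and lower numbers for stronger inhibition), compound 1 gives 49.1 nM. Compound 3 `Cc1ccc(-c2nn(C(C)C)cc2C(=O)N(C)c2ccc(C)c(S(=O)(=O)N3CCOCC3)c2)cc1` differs from compound 1 only by methyl in place of hydrogen on an amide-type nitrogen. In this assay compound 3 gives 489 nM, and the change gives a 10-fold higher number from compound 1 to compound 3 (1.00 log units; beyond the scatter).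

Compound 2 `COc1cccc(Cn2cc(C(=O)Nc3ccc(C)c(S(=O)(=O)N4CCOCC4)c3)c(C(C)C)n2)c1` carries a different core; the difference between the core of compound 1 and the core of compound 2 is not broken down here. In this assay compound 2 gives 199 nM, which lies between the number of compound 1 and the number of compound 3, with both gaps beyond the scatter.

Compound 4 `COc1cccc(Cn2cc(C(=O)N(C)c3ccc(C)c(S(=O)(=O)N4CCOCC4)c3)c(C(C)C)n2)c1` is the unmeasured member. It differs from compound 2 by methyl in place of hydrogen on an amide-type nitrogen. The place of this change is described in the same words as for the change from compound 1 to compound 3, so the same change is made on the second core. Among the compounds shown, this change occurs twice, and only one of the two instances has been measured, so the expectation for compound 4 rests on a single step.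

Because the same change gave a 10-fold higher number from compound 1 to compound 3 (1.00 log units; beyond the scatter), a step of roughly a 10-fold higher number from compound 2 to compound 4 (1.00 log units; beyond the scatter) is expected from compound 2 to compound 4 in this assay. For the measured compounds named here, compound 4 is therefore estimated at 2000 nM in this assay, with an expected range from 700 nM to 6000 nM that is kept wide since only one measured step supports the transfer between cores.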

Compound 4, half-maximal inhibitory concentration: 5330 nM
Compound 4: middle estimate off by 2.7-fold (0.43 log units), on the low side, and the stated range covers the measured number.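

In this assay, methyl in place of hydrogen on an amide-type nitrogen gives a 27-fold higher number from compound 2 to compound 4 (1.43 log units; beyond the scatter), so the step on the core of compound 2 runs in the same direction as the step on the core of compound 1. The direction of the change carries from one core to the other in this pair, but its size does not carry over unchanged: the same change on two cores in this assay, a 10-fold higher number (1.00 log units; beyond the scatter) from compound 1 to compound 3 and a 27-fold higher number (1.43 log units; beyond the scatter) from compound 2 to compound 4, 2.7-fold (0.43 log units) apart, beyond the scatter of two such steps. For the compounds shown here, with only two cores and one instance of the change on each, the result does not show why the two steps differ in size, nor what size to expect on a third core, so a transfer can be trusted for direction more than for magnitude.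

The compounds shown leave open whether ethyl or a longer chain in place of the amide hydrogen would give a step of the same direction and size on either core. They also leave open which of the several differences between the core of compound 1 and the core of compound 2 goes with the gap between the two steps.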